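The source may hold more compounds than are shown below. What is called first, only, known or untested is meant among the compounds shown, and "the series" means these compounds.

Of the compounds shown here, two with the same core have so far been tested in a functional assay on HCT-116 cells (Homo sapiens) for inhibition, with a stated time of 72 h; on this read-out lower numbers stand for stronger inhibition and higher numbers for weaker inhibition. In that test, compound 1 `NC1CCC(Nc2nc(NCc3ccc(-c4cccc(F)c4)nc3)c3ncn(C4CCCC4)c3n2)CC1` gives 74 nM and compound 2 `NC1CCC(Nc2nc(NCc3ccc(-c4cccs4)nc3)c3ncn(C4CCCC4)c3n2)CC1` gives 97 nM. The measured step is a 1.3-fold higher number from compound 1 to compound 2 (0.12 log units; within the scatter), so compound 2 stands level with compound 1, the only other measured point.

Compound 3 `NC1CCC(Nc2nc(NCc3ccc(-c4ccsc4)nc3)c3ncn(C4CCCC4)c3n2)CC1` carries one further change: thiophen-3-yl in place of thiophen-2-yl on an aromatic carbon. In words, thiophen-3-yl takes the place of thiophen-2-yl on an aromatic carbon, and the two compounds have the same atoms, joined differently. The group sits on a six-membered aromatic ring with 1 nitrogen, next to the ring nitrogen.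

Going by the values given here, only one measured step bears on this change. Going from compound 1 to compound 2 exchanged a whole ring at this same place, and that step, a 1.3-fold higher number from compound 1 to compound 2 (0.12 log units; within the scatter), stayed small. Nothing measured yet shows how a thiophene responds when its point of attachment moves. With so little evidence, no step beyond the scatter is expected in this assay. The estimated step is a 1.1-fold lower number from compound 2 to compound 3 (0.03 log units; within the scatter). For compound 3 the estimated value is 90 nM, with an expected range from 40 nM to 200 nM.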

Compound 3, half-maximal inhibitory concentration: 145 nM
The estimate for compound 3 lay 1.6-fold (0.21 log units) below the measured number; low and high end bracket the measured number.
By their numbers in this assay, from the lowest: compounds 1, 2 and 3 (each within the scatter of the next).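

Moving the point of attachment of the thiophene, with thiophen-3-yl in place of thiophen-2-yl next to the ring nitrogen, gives a 1.5-fold higher number from compound 2 to compound 3 (0.17 log units; within the scatter) in this assay, so this rearrangement of the same atoms produces no step beyond the usual variation between repeat measurements, something the earlier pair could not show. Exchanging the whole ring, with thiophen-3-yl in place of 3-fluorophenyl, gives a 2.0-fold higher number from compound 1 to compound 3 (0.29 log units; within the scatter), which means that all three aromatic rings tried at this position stand level with one another in this test. Nothing available here offers an explanation for the small differences among these three groups.

The compounds shown carry only aromatic rings at this position, so it remains open whether a group of another kind, such as a primary amine, a carboxylic acid or a longer alkyl chain, would move the number beyond the scatter. From the compounds shown here alone, it is equally open whether a thiophene carrying a methyl group would stay level with these three compounds or separate from them.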